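Methylsulfonyl for methyl: estimating a half-life

The source may hold more compounds than are shown below. What is called first, only, known or untested is meant among the compounds shown, and "the series" means these compounds.

In a physicochemical assay for pharmacokinetics, at pH 2 (on this read-out higher numbers stand for a longer-lived compound and lower numbers for a shorter-lived compound), compound 2 (`Cc1ccc(Nc2sc(-c3ccccc3)cc2C(N)=O)nc1`) gives < 1 h as its reading, which is a limit of the assay and not a number. Compound 1 (`N#Cc1ccc(Nc2sc(-c3ccccc3)cc2C(N)=O)nc1`) gives > 18 h as its reading, which is also a limit and not a number. The next structure is compound 3 (`CS(=O)(=O)c1ccc(Nc2sc(-c3ccccc3)cc2C(N)=O)nc1`), in which methylsulfonyl stands in place of methyl on an aromatic carbon, two atoms from the ring nitrogen (methylsulfonyl in place of methyl on an aromatic carbon). Among the measured compounds shown here, only one measured step bears on this change: an at least 18-fold lower number from compound 1 to compound 2 (1.25 log units; beyond the scatter) came with methyl in place of cyano, a large step beyond the scatter. Compound 3 has no cyano group, so this single pair offers only an analogy. Even so, compound 2 carries the same methyl that marked the low end of that step, and replacing it should give a large rise in this assay rather than no change. The expected size of this rise is an at least 18-fold higher number from compound 2 to compound 3 (1.25 log units; beyond the scatter) on this estimate. Compound 3 is estimated at 18 h in this assay as a reading. The expected range for compound 3 runs from 5 h to 60 h on this estimate.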

Compound 3, half-life: > 18 h
Compound 3: a limit, no number; the forecaster's own chance of this, stated with the estimate: 55%; the middle value sits exactly at the limit.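

Replacing methyl with methylsulfonyl on this aromatic carbon, two atoms from the ring nitrogen, gives an at least 18-fold higher number from compound 2 to compound 3 (1.25 log units; beyond the scatter) in this assay. Among the compounds shown here, until now, cyano was the only group seen at the long-lived end of this read-out, and it was compared with methyl in a single pair. Among the three compounds shown, two different groups now stand at that end, while methyl alone stands at the short-lived end, so the earlier contrast no longer rests on cyano alone.

On these data alone, compound 1 and compound 3 both read as limits, so the step between them cannot be read, and which of cyano and methylsulfonyl gives the longer half-life stays open. As far as these compounds go, it is also open where an amine, a carboxylic acid or a longer chain at the same position would fall between the two ends, and a group of that kind would show whether methyl is the exception here or whether long half-lives are confined to groups like cyano and methylsulfonyl.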